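A second methoxy on the sulfonyl aryl group

This account rests on a few compounds, and the source may have more. Where it says the series, first, only, none or still open, it means among the compounds named here.

Three compounds share one core and differ only in the aryl group on the sulfonyl sulfur. Compound 1 `Cc1ccc(S(=O)(=O)N(C)c2ccc3[nH]c(-c4n[nH]c5ccccc45)cc3n2)cc1` carries a methyl there and gives 3030 nM in a functional assay on HL-60 cells (Homo sapiens) for antiproliferative activity, read by MTT assay, with a stated time of 72 h; a higher number here means a weaker inhibitor, a lower number a stronger inhibitor. Compound 2 `CN(c1ccc2[nH]c(-c3n[nH]c4ccccc34)cc2n1)S(=O)(=O)c1ccc(Cl)cc1` carries a chloro and gives 770 nM in this assay. Compound 3 `COc1ccc(S(=O)(=O)N(C)c2ccc3[nH]c(-c4n[nH]c5ccccc45)cc3n2)cc1` carries a methoxy and gives 4340 nM in this assay, the highest of the three numbers. Its nearest neighbour is compound 1: a 1.4-fold higher number from compound 1 to compound 3 (0.16 log units; within the scatter). Its furthest is compound 2: a 5.6-fold higher number from compound 2 to compound 3 (0.75 log units; beyond the scatter). The third step, a 3.9-fold lower number from compound 1 to compound 2 (0.59 log units; beyond the scatter), is the other modest one in the set.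

Compound 4 `COc1ccc(OC)c(S(=O)(=O)N(C)c2ccc3[nH]c(-c4n[nH]c5ccccc45)cc3n2)c1` differs from compound 3 in one place: 2,5-dimethoxyphenyl in place of 4-methoxyphenyl on a sulfonyl sulfur. Going by the values given here, no measured step touches a second methoxy or a methoxy at another position; every measured step swaps a single group on one and the same carbon. Among the compounds with values here, the steps that bear on compound 4 are thus only those from compound 3, one within the scatter and one modestly beyond it, and neither speaks for a shift in a set direction. Compound 4 is therefore expected to show a 1.1-fold lower number from compound 3 to compound 4 (0.04 log units; within the scatter), a change not beyond the scatter in this assay. Compound 4 is estimated at 4000 nM in this assay, with a range from 1500 nM to 12000 nM.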

Compound 4, half-maximal inhibitory concentration: 840 nM
Estimate against measurement, compound 4: 4.8-fold (0.68 log units) above; the measured number lies below the stated range.
By their numbers in this assay, from the lowest: compounds 2 and 4 (each within the scatter of the next); then compounds 1 and 3 (each within the scatter of the next).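

In this assay, going by these compounds alone, 2,5-dimethoxyphenyl in place of 4-methoxyphenyl on the sulfonyl sulfur gives a 5.2-fold lower number from compound 3 to compound 4 (0.71 log units; beyond the scatter), the first step in this set that changes more than a single group on one carbon of the aryl group, and it shows that a methoxy-bearing aryl group at this position does not have to stay with the higher numbers. The 4-chlorophenyl group of compound 2 is no longer alone at the low end of the set: the change to the dimethoxy group gives a 1.1-fold higher number from compound 2 to compound 4 (0.04 log units; within the scatter), while the change from the 4-methylphenyl group gives a 3.6-fold lower number from compound 1 to compound 4 (0.56 log units; beyond the scatter), so two quite different aryl groups now stand within the scatter of each other. Nothing measured here explains this result, and no outside data on these compounds bear on it.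

The compounds shown leave open whether the step from compound 3 belongs to the added methoxy or to the new arrangement of the two methoxy groups on the ring. Also open, from the compounds shown here alone, is how an amine, a carboxylic acid or a longer chain such as ethoxy on this aryl group would compare with compound 4.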